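Changing One Side Group in a Tightly Bound Pair

This account rests on a few compounds, and the source may have more. Where it says the series, first, only, none or still open, it means among the compounds named here.

In an ADME assay on a cell-free system (plasma, Homo sapiens) for protein binding, compound 1 `Cc1cc(Nc2ccc(S(F)(F)(F)(F)F)cc2)n2nc(C3CC3)nc2n1` gives 97.7%. Compound 2 `CSc1nc2nc(C)cc(Nc3ccc(S(F)(F)(F)(F)F)cc3)n2n1` gives 97.7%, which is level with compound 1 at the digits shown. Compound 3 `COCc1nc2nc(C)cc(Nc3ccc(S(F)(F)(F)(F)F)cc3)n2n1` has not yet been measured. It carries methoxymethyl in place of methylsulfanyl on an aromatic carbon. Among the measured compounds shown here, one measured step bears on this change, methylsulfanyl in place of cyclopropyl on an aromatic carbon, and it shows no change at the digits printed from compound 1 to compound 2 (within the scatter). That step leaves methoxymethyl untested, so it is only a loose guide. A small move toward more free compound is expected in this assay, and it may well stay within the scatter. The estimated size of the move is a 1.5-fold higher unbound fraction from compound 2 to compound 3 (0.18 log units; within the scatter). For compound 3 the estimate is 96.5%, with an expected range from 93% to 98.5%.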

Compound 3, plasma protein binding: 91.7%
For compound 3 the middle estimate is 2.4-fold (0.38 log units) (unbound fraction) below the measured one; measured number outside the range, below it.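

In this assay this position, on an aromatic carbon of the five-membered ring, turns out to respond to the group it carries: methoxymethyl in place of methylsulfanyl gives a 3.6-fold higher unbound fraction from compound 2 to compound 3 (0.56 log units; beyond the scatter) and methoxymethyl in place of cyclopropyl gives a 3.6-fold higher unbound fraction from compound 1 to compound 3 (0.56 log units; beyond the scatter), a step of the same printed size. The level readings of compound 1 and compound 2 therefore held for that pair of groups only and did not mean that any group here would give the same binding. No measurement available here explains why compound 3 leaves more of the compound free.

From the compounds shown here alone, with a single compound carrying methoxymethyl, it stays open whether the ring-bound chain or its oxygen matters more. Going by these compounds, it also stays open how an amine, a carboxylic acid or a longer ether chain at this place would compare.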